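A few compounds are considered here, and "the series" means these few. Any claim that something is new, unique, unknown or untested is made for them only; others in the source may bear on it.

Compound 1, `Cn1c(=O)c2c(cc(/C=C/c3ccc(S(C)(=O)=O)cc3)n2C)n(C)c1=O`: > 1000 nM in an assay on isolated protein for inhibition of Amine oxidase [flavin-containing] B (Homo sapiens), read by luminescence, with a stated time of 1 h; a lower number here means a stronger inhibitor, a higher number a weaker inhibitor; this value is a limit of the assay, not a number.
Compound 2, `Cn1c(=O)c2c(cc(C#Cc3cccc(Cl)c3)n2C)n(C)c1=O`: 173 nM
Compound 3, `Cn1c(=O)c2c(cc(OCc3ccc(Cl)cc3)n2C)n(C)c1=O`: 48.1 nM

Of the two compounds with a number in this assay, compound 3 gives the lowest, and compound 2 gives a higher one; the gap between them is beyond the usual scatter. Compound 4, `Cn1c(=O)c2c(cc(OCc3ccc(Cl)c(C(F)(F)F)c3)n2C)n(C)c1=O`, has not yet been measured in this assay. It differs from compound 3 in one place: trifluoromethyl in place of hydrogen on an aromatic carbon. Among the measured compounds shown here, no measured pair shows this same change, so its effect is not known from these data. A small step is expected, perhaps toward a lower number, but one that may well stay within the scatter, and the step from compound 3 to compound 4 is estimated at a 1.2-fold lower number from compound 3 to compound 4 (0.08 log units; within the scatter). In this assay compound 4 is therefore expected to give about 40 nM, likely between 10 nM and 160 nM.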

Compound 4, half-maximal inhibitory concentration: 583 nM
Estimate against measurement, compound 4: 15-fold (1.16 log units) below; the measured number lies above the stated range.
By their numbers in this assay, from the lowest: compound 3; then compound 2; then compound 4. At a limit, above all of these: compound 1.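

In this assay, trifluoromethyl is poorly tolerated at this aromatic carbon ortho to a chloro group: the change gives a 12-fold higher number from compound 3 to compound 4 (1.08 log units; beyond the scatter). Among the compounds shown here, the earlier compounds included no pair differing in one place, so this is the first direct reading of a single change, and here hydrogen clearly does better. Both values are numbers, so the assay ceiling does not cut this step short: the limit of > 1000 nM in this assay, at which 1 of the 4 values shown sits.

On these data alone, whether this high cost belongs to trifluoromethyl alone stays open. A fluorine, a methyl group or a methoxy group on the same carbon could show how other substituents behave there.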